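A few compounds are considered here, and "the series" means these few. Any claim that something is new, unique, unknown or untested is made for them only; others in the source may bear on it.

Measured in a functional assay on U-251 cells (Homo sapiens) for antiproliferative activity, read by MTT assay, with a stated time of 24 h; on this read-out higher numbers stand for weaker inhibition and lower numbers for stronger inhibition:
- compound 1 `COc1cc(OC)c(-c2coc3cc(OCc4ccccc4)ccc3c2=O)cc1OC`: 6750 nM
- compound 2 `COc1cc(OC)c(-c2coc3cc(OCc4ccc(Cl)cc4)ccc3c2=O)cc1OC`: 470 nM
- compound 3 `COc1cc(OC)c(-c2coc3cc(OCc4cccc(Br)c4)ccc3c2=O)cc1OC`: > 10000 nM

Among the measured compounds shown here, compound 3 stands at a limit of this assay, with > 10000 nM as its only reading.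

Compound 4 `COc1cc(OC)c(-c2coc3cc(OCc4ccc(C(F)(F)F)cc4)ccc3c2=O)cc1OC` differs from it as follows: 4-(trifluoromethyl)phenyl in place of 3-bromophenyl on a saturated chain carbon bound to an oxygen on an aromatic ring. Thus 4-(trifluoromethyl)phenyl replaces 3-bromophenyl on a saturated chain carbon bound to an oxygen on an aromatic ring.

For the measured compounds named here, three measured steps bear on this. The large step of a 14-fold lower number from compound 1 to compound 2 (1.16 log units; beyond the scatter) came with a 4-chlorophenyl group, and the large step of an at least 21-fold higher number from compound 2 to compound 3 (1.32 log units; beyond the scatter) separates that group from 3-bromophenyl. The step of an at least 1.4-fold higher number from compound 1 to compound 3 (0.17 log units; that floor lies within the scatter) has a floor within the scatter.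

The closest guide is compound 2 at 470 nM, so a sizeable move to a lower number is expected in this assay. The expected step is an at least 6.6-fold lower number from compound 3 to compound 4 (0.82 log units; beyond the scatter). For compound 4 the estimated value is 1500 nM, with an expected range of 250 nM to 9000 nM.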

Compound 4, half-maximal inhibitory concentration: 3750 nM
Compound 4: the middle estimate sits 2.5-fold (0.40 log units) below what was measured, within the range that was stated.
By their numbers in this assay, from the lowest: compound 2; then compounds 4 and 1 (each within the scatter of the next). At a limit, above all of these: compound 3.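

In this assay, the gain seen with 4-chlorophenyl does not carry over to 4-(trifluoromethyl)phenyl at this position: an 8.0-fold higher number from compound 2 to compound 4 (0.90 log units; beyond the scatter), while a 1.8-fold lower number from compound 1 to compound 4 (0.26 log units; within the scatter). Against 3-bromophenyl, an at least 2.6-fold lower number from compound 3 to compound 4 (0.42 log units; beyond the scatter), and this is only a floor. The reading for compound 3 is a limit, not a number: the limit of > 10000 nM in this assay, at which 1 of the 4 values shown sits.

From the compounds shown here alone, compounds 2 and 3 differ in both the halogen and its place on the ring, so the contribution of each remains open. A 4-bromophenyl or 3-chlorophenyl group would separate the two, and a 4-aminophenyl group would test an amine at this position.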